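The compounds below may be only part of what the source reports. "The series", "measured", "known", "first", "only" and "open" are said of these compounds alone.

For the measured compounds named here, compound 2 `O=S(=O)(NCCNc1nccc(-c2c(-c3cccc(F)c3)nc3sccn23)n1)c1ccc(Br)cc1` gives the highest of the three numbers measured so far in a functional assay on SK-MEL-28 cells (Homo sapiens) for cytotoxicity, read by MTT assay (a lower number here means a stronger inhibitor, a higher number a weaker inhibitor), where compound 2 gives 13500 nM. Its nearest neighbour is compound 1 `O=S(=O)(NCCCNc1nccc(-c2c(-c3cccc(F)c3)nc3sccn23)n1)c1ccc(Br)cc1`, which in this assay gives 9400 nM, the step from the longer chain to the shorter one being a 1.4-fold higher number from compound 1 to compound 2 (0.16 log units; within the scatter). Compound 3 `O=S(=O)(NCCCNc1nccc(-c2c(-c3cccc(F)c3)nc3sccn23)n1)c1ccc(Cl)cc1` gives 8450 nM in this assay, and the step of a 1.6-fold lower number from compound 2 to compound 3 (0.20 log units; within the scatter) is likewise within the scatter, so none of the three stands apart from the others.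

Compound 4 `O=S(=O)(NCCNc1nccc(-c2c(-c3cccc(F)c3)nc3sccn23)n1)c1ccccc1` is compound 2 with one change: hydrogen in place of bromo on an aromatic carbon. Going by the values given here, the only measured step that touches the same position is the exchange of one halogen for another, a 1.1-fold lower number from compound 1 to compound 3 (0.05 log units; within the scatter), which stayed within the scatter. Among the compounds with values here, no measured pair removes a halogen altogether, so the effect of losing the bromo group entirely rests on that single halogen swap. Given that the steps among compounds 1, 2 and 3 all lie within the scatter, a step of a 1.2-fold higher number from compound 2 to compound 4 (0.07 log units; within the scatter) is expected, with no change beyond the scatter as the most likely outcome and a drift toward a somewhat higher number as the secondary possibility. Compound 4 is therefore estimated at 16000 nM in this assay, with a range from 7500 nM to 35000 nM.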

Compound 4, half-maximal inhibitory concentration: 19000 nM
The estimate for compound 4 lay 1.2-fold (0.07 log units) below the measured number; the range from low to high includes it.
By their numbers in this assay, from the lowest: compounds 3, 1, 2 and 4 (each within the scatter of the next, the first and the last beyond it).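

Replacing the bromo group with hydrogen on the aromatic carbon para to a large group gives a 1.4-fold higher number from compound 2 to compound 4 (0.15 log units; within the scatter) in this assay so on the shorter chain, 4-bromophenyl can give way to phenyl with no change beyond the scatter. Two steps do pass beyond the scatter, however: a 2.0-fold higher number from compound 1 to compound 4 (0.31 log units; beyond the scatter) and a 2.2-fold higher number from compound 3 to compound 4 (0.35 log units; beyond the scatter) are both modest and both join the shorter chain to the loss of the halogen, whereas neither the chain change from compound 1 to compound 2 nor the loss of bromo from compound 2 does so alone. No outside evidence bears on these results, so the reason for these steps remains unknown.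

The compounds shown leave open whether a phenyl compound on the longer chain would stay close to compound 1 and compound 3 or to compound 4, which would separate the effect of the chain from that of the halogen. They also leave open what a methoxy group, an amine or a carboxylic acid would do in place of bromo on that aromatic carbon, and what a chain longer than that of compound 1 would do.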